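A few compounds are considered here, and "the series" means these few. Any claim that something is new, unique, unknown or untested is made for them only; others in the source may bear on it.

In a functional assay on A549 cells (Homo sapiens) for cytotoxicity, read by MTT assay, with a stated time of 72 h (on this read-out higher numbers stand for weaker inhibition and lower numbers for stronger inhibition), compound 2 `COc1cc2c(Oc3ccc(NC(=O)N/N=C/c4ccc(O)cc4)cc3F)ccnc2cc1OCCCN1CCCCC1` gives 780 nM, and compound 1 `COc1ccc(/C=N/NC(=O)Nc2ccc(Oc3ccnc4cc(OCCCN5CCCCC5)c(OC)cc34)c(F)c2)cc1` gives 540 nM; the step of a 1.4-fold higher number from compound 1 to compound 2 (0.16 log units; within the scatter) lies within the scatter, so compound 2 stands alongside compound 1 rather than apart from it. Compound 3 `C=CCc1cccc(/C=N/NC(=O)Nc2ccc(Oc3ccnc4cc(OCCCN5CCCCC5)c(OC)cc34)c(F)c2)c1OC` carries 3-allyl-2-methoxyphenyl in place of 4-hydroxyphenyl on a carbon with a double bond to nitrogen. For the measured compounds named here, only one measured step bears on this change, a 1.4-fold higher number from compound 1 to compound 2 (0.16 log units; within the scatter), which swapped hydrogen for methyl on an aromatic oxygen and stayed within the scatter; the allyl group that enters has no measured counterpart. The step expected for compound 3 is therefore a 1.3-fold lower number from compound 2 to compound 3 (0.11 log units; within the scatter), nothing beyond the scatter. Compound 3 is estimated at 600 nM, between 250 nM and 1500 nM.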

Compound 3, half-maximal inhibitory concentration: 250 nM
Compound 3: middle estimate off by 2.4-fold (0.38 log units), on the high side; low and high end bracket the measured number.
By their numbers in this assay, from the lowest: compound 3; then compounds 1 and 2 (each within the scatter of the next).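

At the carbon with a double bond to nitrogen, the earlier change on the aromatic oxygen stayed within the scatter, but a larger replacement does not: in this assay, 3-allyl-2-methoxyphenyl in place of 4-hydroxyphenyl gives a 3.1-fold lower number from compound 2 to compound 3 (0.49 log units; beyond the scatter), and in place of 4-methoxyphenyl it gives a 2.2-fold lower number from compound 1 to compound 3 (0.33 log units; beyond the scatter). Both steps run the same way, so this position responds to the aromatic group it carries. No measurement shown accounts for this result. The compounds shown leave open whether the allyl group itself matters, as no compound separates it from the rest of the new group. A propyl chain or an amine in its place would test this.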